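Acid replacements on the benzyloxy tail of the pyroglutamide series

A few compounds are considered here, and "the series" means these few. Any claim that something is new, unique, unknown or untested is made for them only; others in the source may bear on it.

compound 1 `O=C(NCc1ccccc1)[C@@H]1CCC(=O)N1Cc1ccccc1`: a limit, > 5000 nM
compound 2 `O=C(NO)c1ccc(COc2ccc(CNC(=O)[C@@H]3CCC(=O)N3Cc3ccccc3)cc2)cc1`: 700 nM
compound 3 `O=C(NCc1ccc(OCc2ccc(-c3nn[nH]n3)cc2)cc1)[C@@H]1CCC(=O)N1Cc1ccccc1`: a limit, > 5000 nM

In an assay on HEK293 cells for inhibition of Ataxin-2 (Mus musculus), read by fluorescence and Amplex Red (a lower number here means a stronger inhibitor, a higher number a weaker inhibitor), compound 3 sits at a limit, > 5000 nM; it shares that position with compound 1, as the limit of > 5000 nM in this assay, at which 2 of the 3 values shown sit, records. Compound 4 `O=C(NCc1ccc(OCc2ccc(B(O)O)cc2)cc1)[C@@H]1CCC(=O)N1Cc1ccccc1` carries a group of 3 heavy atoms (1 boron, 2 oxygen; no ring) in place of a group of 5 heavy atoms (1 carbon, 4 nitrogen; one five-membered aromatic ring with 4 hetero atoms), on an aromatic carbon. For the measured compounds named here, the one step that bears on this place is an at least 7.1-fold higher number from compound 2 to compound 3 (0.85 log units; beyond the scatter), which moved the series from a measured number to a limit. Going by the values given here, compound 4 exchanges one acid-type group for another at that same carbon; no measured pair shows what that exchange does. Compound 4 is therefore expected near the limit again, giving a step that the limit leaves unreadable from compound 3 to compound 4 of little size. Compound 4 is estimated at 6000 nM, between 1500 nM and 20000 nM.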

Compound 4, half-maximal inhibitory concentration: 35 nM
The estimate for compound 4 lay 170-fold (2.23 log units) above the measured number; measured number below the stated range.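

In this assay, what sits at this aromatic carbon decides the outcome: the boron-bearing group gives an at least 140-fold lower number from compound 3 to compound 4 (2.15 log units; beyond the scatter) and a 20-fold lower number from compound 2 to compound 4 (1.30 log units; beyond the scatter). The whole tail ending in this group gives an at least 140-fold lower number from compound 1 to compound 4 (2.15 log units; beyond the scatter), while the same tail ending in 2H-tetrazol-5-yl does not leave the limit. Compound 1 and compound 3 remain limits, not numbers: the limit of > 5000 nM in this assay, at which 2 of the 4 values shown sit.

Open, from the compounds shown here alone, is whether a carboxylic acid at this carbon would behave like the boron-bearing group or like 2H-tetrazol-5-yl. Also open, going by these compounds, is whether an amine there would keep any of the gain.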